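Aryl swap on the pyrimidine core of compound 1

The source may hold more compounds than are shown below. What is called first, only, known or untested is meant among the compounds shown, and "the series" means these compounds.

Measured so far:
- compound 1, `COc1ccc(-c2ccnc(Nc3ccc([N+](=O)[O-])cc3)n2)cc1`: 537 nM
- compound 2, `COc1ccc(-c2ccnc(Nc3ccc(Cl)cc3)n2)cc1`: 603 nM

In an assay on isolated protein for inhibition of phosphatidylinositol 4,5-bisphosphate 3-kinase catalytic subunit beta isoform (Homo sapiens) (on this read-out lower numbers stand for stronger inhibition and higher numbers for weaker inhibition), compound 1 gives 537 nM, the lower of the two numbers; compound 2 gives 603 nM, and the step of a 1.1-fold higher number from compound 1 to compound 2 (0.05 log units; within the scatter) is within the scatter, so the two compounds cannot be ordered.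

Compound 3, `O=[N+]([O-])c1ccc(Nc2nccc(-c3ccc(Cl)cc3Cl)n2)cc1`, is not yet measured. It differs from compound 1 by 2,4-dichlorophenyl in place of 4-methoxyphenyl on an aromatic carbon. Within the data shown here, no measured step touches that ring: the only step, from compound 1 to compound 2, changes the substituent on the aniline ring and was within the scatter, so it gives no guidance on the size or direction of the present change. The expectation for compound 3 therefore rests on compound 1 alone, with a wide range.

For compound 3 in this assay a value of about 800 nM is expected, within 200 nM to 3200 nM.

The step of a 1.5-fold higher number from compound 1 to compound 3 (0.17 log units; within the scatter) is estimated as no change beyond the scatter.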

Compound 3, half-maximal inhibitory concentration: 938 nM
Estimate against measurement, compound 3: 1.2-fold (0.07 log units) below, within the range that was stated.
By their numbers in this assay, from the lowest: compounds 1, 2 and 3 (each within the scatter of the next).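

In this assay, among these compounds, 2,4-dichlorophenyl in place of 4-methoxyphenyl on the aromatic carbon next to the ring nitrogen gives a 1.7-fold higher number from compound 1 to compound 3 (0.24 log units; within the scatter), which is the first reading at this position, as the earlier step changed only the aniline ring. The swap exchanges a group with 1 hydrogen-bond acceptor for one with 0 at an equal heavy-atom count, and for this single pair the number stays within the scatter. Nothing available explains this result.

The compounds shown leave open whether this position responds at all to a group of a different kind, such as a morpholine or a carboxylic acid on the phenyl ring. They also leave open how 2,4-dichlorophenyl behaves alongside chloro rather than nitro on the aniline ring.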